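This account rests on a few compounds, and the source may have more. Where it says the series, first, only, none or still open, it means among the compounds named here.

Of the compounds shown here, three sharing one core have been measured so far. In a functional assay on V79 cells (Cricetulus griseus) for cytotoxicity, read by colony formation (on this read-out higher numbers stand for weaker inhibition and lower numbers for stronger inhibition), compound 1 `CC1(n2cc(C(=O)O)c(=O)c3cc(F)c(N4CCC(N)C4)c(F)c32)CC1` gives 160 ug/mL, compound 2 `O=C(O)c1cn(C2CC2)c2c(F)c(N3CCCC3)c(F)cc2c1=O` gives 120 ug/mL and compound 3 `O=C(O)c1cn(C2CC2)c2c(Cl)c(N3CCCC3)c(F)cc2c1=O` gives 150 ug/mL. Compound 3 lies within the usual scatter of both others, so these numbers set the three compounds in no real order.

Compound 4 `O=C(O)c1cn(C2CC2)c2c(C(F)(F)F)c(N3CCCC3)c(F)cc2c1=O` differs from compound 3 in a single group: trifluoromethyl in place of chloro on an aromatic carbon, ortho to a pyrrolidin-1-yl group. The counted change is trifluoromethyl in place of chloro on an aromatic carbon.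

For the measured compounds named here, only one measured step concerns the same aromatic carbon. Chloro in place of fluoro there gave a 1.3-fold higher number from compound 2 to compound 3 (0.10 log units; within the scatter). Going by the values given here, that is one small step, and no measured compound carries a trifluoromethyl group, so the data offer no direct guide to this exchange. The new group is also larger by count than either halogen tested at this place, which argues for a wide range rather than a confident direction.

No shift beyond the scatter is therefore expected in this assay. The estimated change is a 1.1-fold lower number from compound 3 to compound 4 (0.05 log units; within the scatter), a step with no firm direction. For compound 4 the expected value is 135 ug/mL, with an estimated range from 65 ug/mL to 280 ug/mL.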

Compound 4, half-maximal inhibitory concentration: 280 ug/mL
Compound 4: middle estimate off by 2.1-fold (0.32 log units), on the low side, within the range that was stated.
By their numbers in this assay, from the lowest: compounds 2, 3, 1 and 4 (each within the scatter of the next, the first and the last beyond it).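

In this assay, trifluoromethyl in place of chloro on this aromatic carbon gives a 1.9-fold higher number from compound 3 to compound 4 (0.27 log units; within the scatter), so this exchange alone does not clearly separate the two compounds. The comparison with fluoro at the same carbon says more: trifluoromethyl in place of fluoro gives a 2.3-fold higher number from compound 2 to compound 4 (0.37 log units; beyond the scatter), a modest step and the first at this place to pass beyond the scatter, since the earlier step of a 1.3-fold higher number from compound 2 to compound 3 (0.10 log units; within the scatter) stayed within it. Of the three groups tested here, only fluoro and trifluoromethyl are told apart, with weaker inhibition for the trifluoromethyl compound, and nothing shown offers a measured explanation for that difference.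

The compounds shown leave open how other groups on this carbon would read, such as a methyl, a methoxy, a nitrile or an amine, and whether the trend among the three groups would hold for them. On these data alone, it also remains open whether trifluoromethyl would give a similar step when the pyrrolidin-1-yl group carries an amine, as the ring in compound 1 does.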